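The source may hold more compounds than are shown below. What is called first, only, known or untested is meant among the compounds shown, and "the series" means these compounds.

Measured compounds and their values:

- Compound 1, `Nc1ccccc1S(=O)(=O)N1CC(n2cnc3c(Cl)nc(Cl)nc32)OCc2ccccc21`: 467 nM
- Compound 2, `O=[N+]([O-])c1ccccc1S(=O)(=O)N1CC(n2cnc3c(I)nc(Cl)nc32)OCc2ccccc21`: 256 nM
- Compound 3, `c1ccc(Sc2nc(Sc3ccccc3)c3ncn(C4CNc5ccccc5CO4)c3n2)cc1`: "not determined" (no result reported)

These three compounds were examined in a functional assay on MDA-MB-231 cells (Homo sapiens) for cytotoxicity, read by sulforhodamine B assay, with a stated time of 3 days; on this read-out lower numbers stand for stronger inhibition and higher numbers for weaker inhibition. Compound 1 gives 467 nM in this assay, the higher of the two numbers available, while compound 2 gives 256 nM; the gap between these two lies within the scatter of this kind of measurement, so no order can be read from them. Compound 3 has no result in this assay.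

The step of interest leads from compound 1 to compound 4, `O=[N+]([O-])c1ccc(S(=O)(=O)N2CC(n3cnc4c(Cl)nc(Cl)nc43)OCc3ccccc32)cc1`. The change is 4-nitrophenyl in place of 2-aminophenyl on a sulfonyl sulfur. Within the data shown here, no step between two measured compounds with a single change is available, so the size of this step can only be expected from what compound 1 and compound 2 show. Since both measured numbers sit close together, the step from compound 1 to compound 4 is expected to be small, at most a modest move toward a lower number, a 1.3-fold lower number from compound 1 to compound 4 (0.13 log units; within the scatter). Compound 4 is therefore estimated at 350 nM, within a range from 120 nM to 1000 nM.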

Compound 4, half-maximal inhibitory concentration: 166 nM
Estimate against measurement, compound 4: 2.1-fold (0.32 log units) above; measured number inside the range.
By their numbers in this assay, from the lowest: compounds 4, 2 and 1 (each within the scatter of the next, the first and the last beyond it).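

In this assay, a 2.8-fold lower number from compound 1 to compound 4 (0.45 log units; beyond the scatter). This is a modest step, but it lies beyond the scatter, so the group on the sulfonyl sulfur can shift the number, something the earlier values, all within the scatter of each other, could not show. No measurement at hand explains this shift.

The step replaces the amino group with a nitro group and also moves the substituent on the phenyl ring, so the compounds shown do not separate the two changes; a 4-aminophenyl or a 2-nitrophenyl group on the core of compound 1 would be needed to tell them apart. From the compounds shown here alone, it also remains open how a plain phenyl ring, a 4-methoxyphenyl group or a small methyl group on the same sulfur would compare.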